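Imine esters: bromo for dimethylamino at the aromatic carbon

The source may report more compounds than this note shows. Statements on the series, on what has been measured and on what is new or still open speak of the compounds shown alone.

Three esters of the shared core have numbers in a functional assay on the whole organism (strain Wistar CF) for inhibition, with Rattus norvegicus as the target, read by paw edema, with a stated time of 1 h, at a dose of 100 mg/kg by the oral route; on this read-out higher numbers stand for more inhibition at the one dose given (going by the name of the read-out) and lower numbers for less inhibition. Compound 1 `COc1ccc(/C=N/c2ccc(OC(=O)C(C)c3ccc(CC(C)C)cc3)cc2)cc1` gives 54%. Compound 2 `CC(C)Cc1ccc(C(C)C(=O)Oc2ccc(/N=C/c3ccc([N+](=O)[O-])cc3)cc2)cc1` gives 29.9%, and compound 3 `CC(C)Cc1ccc(C(C)C(=O)Oc2ccc(/N=C/c3ccc(N(C)C)cc3)cc2)cc1` gives 71.7%, the highest of the three, beyond the scatter from both. The change from compound 1 to compound 2 is a nitro in place of methoxy on an aromatic carbon, with a number 24.1 percentage points lower from compound 1 to compound 2 (beyond the scatter). Swapping the methoxy for a dimethylamino gives a number 17.7 percentage points higher from compound 1 to compound 3 (beyond the scatter), and swapping the nitro for a dimethylamino gives a number 41.8 percentage points higher from compound 2 to compound 3 (beyond the scatter).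

Compound 4 `CC(C)Cc1ccc(C(C)C(=O)Oc2ccc(/N=C/c3ccc(Br)cc3)cc2)cc1` is not yet measured. It differs from compound 3 by bromo in place of dimethylamino on an aromatic carbon. Within the data shown here, no measured step introduces a bromo, so the steps from compound 1 and compound 2 into compound 3 bear only indirectly: both show that dimethylamino at this aromatic carbon stands highest, and every replacement so far measured lowers the number. A step of moderate size downward is therefore expected, a number 26.7 percentage points lower from compound 3 to compound 4 (beyond the scatter), toward the range of compound 1 and compound 2. Compound 4 is estimated at 45%, within 30% to 60%.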

Compound 4, a percentage reported as inhibition, in the whole organism at one dose (the size of the read-out at that dose, not a potency): 36.5%
For compound 4 the middle estimate is 8.5 percentage points above the measured one; measured number inside the range.
By their numbers in this assay, from the lowest: compounds 2 and 4 (each within the scatter of the next); then compound 1; then compound 3.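

In this assay, bromo on this aromatic carbon, para to a large group, gives a number 35.2 percentage points lower from compound 3 to compound 4 (beyond the scatter), and replacing methoxy with it gives a number 17.5 percentage points lower from compound 1 to compound 4 (beyond the scatter), so the single halogen shown sits lower than both electron-rich-free comparisons would settle only by number, not by kind. Against nitro, the same position shows a number 6.6 percentage points higher from compound 2 to compound 4 (within the scatter), so bromo and nitro cannot be ordered here, and compound 3 with its dimethylamino remains clearly highest among the four. Nothing at hand explains these differences.

As far as these compounds go, whether chloro, fluoro or a primary amine at this carbon would fall near compound 4 or near compound 3 remains open. Also open, from the compounds shown here alone, is whether diethylamino or a cyclic amine such as pyrrolidine would hold the number reached with dimethylamino.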